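The compounds below may be only part of what the source reports. "The series", "measured", "known", "first", "only" and "open" are said of these compounds alone.

Measured so far in an ADME assay on HepG2 cells (Homo sapiens) for cytotoxicity, read by CellTiter-Glo and resazurin assay, with a stated time of 72 h; a higher number here means that more compound is needed for the effect, a lower number that less compound is needed:
- compound 1 `COc1cc(OC)cc(-c2ccc(C(=O)N(Cc3cccc(OCCCCCC(=O)O)c3)C(C)C)cc2)c1`: > 26000 nM, a limit of the assay
- compound 2 `CCOC(=O)CCCCCOc1cccc(CN(C(=O)c2ccc(-c3ccc(C(C)=O)s3)cc2)C(C)C)c1`: > 26000 nM, a limit of the assay
- compound 3 `CCOC(=O)CCCCCOc1cccc(CN(C(=O)c2ccc(-c3ccc4cc[nH]c4c3)cc2)C(C)C)c1`: > 26000 nM, a limit of the assay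

Compound 3 stands where the other two stand: only a limit is known for it, and all three values sit at the same limit (the limit of > 26000 nM in this assay, at which 3 of the 3 values shown sit). The change from compound 2 to compound 3, a step that the two limits leave unreadable from compound 2 to compound 3, therefore cannot be sized; both ends of it are limits.

Compound 4 `CCOC(=O)CCCCCOc1cccc(CN(C(=O)c2ccc(-c3cc(OC)cc(OC)c3)cc2)C(C)C)c1` is the next member. The change from compound 3 is 3,5-dimethoxyphenyl in place of 1H-indol-6-yl on an aromatic carbon. Going by the values given here, the only measured step that bears on it is the one from compound 2 to compound 3, and that one is unreadable in this assay; compound 1, which already carries the 3,5-dimethoxyphenyl group, gives only a limit as well. Among the compounds with values here, no measured step in this assay shows a readable move beyond the scatter, so none is expected here either.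

Compound 4 is therefore expected to stay at or beyond the assay limit, estimated at 40000 nM (range 15000 nM to 150000 nM), which would mean an expected step that the limit leaves unreadable from compound 3 to compound 4 from compound 3 to compound 4.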

Compound 4, half-maximal effective concentration: > 26000 nM
Compound 4 ended at the assay's limit; the forecaster's own chance of this, stated with the estimate: 85%; the middle value lies beyond the limit too.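

The steps from compound 1, compound 2 and compound 3 to compound 4 cannot be read in this assay, with both ends of each step being limits: the limit of > 26000 nM in this assay, at which 4 of the 4 values shown sit.

The compounds shown leave open at what concentration any of them reaches the half-maximal effect in this assay and whether changing the aromatic group or the ethyl ester moves it at all.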